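The compounds below may be only part of what the source reports. "The series", "measured", "known", "first", "only" and "open" are said of these compounds alone.

Measured so far in a functional assay on HL-60 cells (Homo sapiens) for antiproliferative activity, read by MTT assay; a higher number here means a weaker inhibitor, a lower number a stronger inhibitor:
- compound 1 `O[C@@H]1[C@@H](OCc2ccccc2)[C@H](OCc2ccccc2)[C@@H](COCc2ccccc2)O[C@H]1CC1CCCCC1`: 4100 nM
- compound 3 `O[C@@H]1[C@@H](OCc2ccccc2)[C@H](OCc2ccccc2)[C@@H](COCc2ccccc2)O[C@@H]1CC1CCCCC1`: 17200 nM
- compound 2 `c1ccc(COC[C@H]2O[C@H]3C[C@H]3[C@@H](OCc3ccccc3)[C@@H]2OCc2ccccc2)cc1`: "not active" (no number reported), reported without a number

Compound 1 holds the lowest of the two numbers in this assay. Going by the values given here, its nearest neighbour is compound 3, and the step of a 4.2-fold higher number from compound 1 to compound 3 (0.62 log units; beyond the scatter) is the only measured step in the set; it rests on (the fact that compounds 1 and 3 differ only in the configuration as drawn), the two compounds being identical in atoms and bonds.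

Compound 4 `O[C@@H]1[C@@H](OCc2ccccc2)[C@H](OCc2ccccc2)[C@@H](COCc2ccccc2)O[C@H]1Cc1ccccc1` is still to be measured in this assay. It differs from compound 1 by phenyl in place of cyclohexyl on a saturated chain carbon bound to a saturated ring carbon. Among the compounds with values here, no measured step touches this change: the only measured pair, compound 1 and compound 3, differs in configuration, not in the substituent on the saturated chain carbon, and compound 2 offers no number. Nothing in the set therefore points to a step in either direction for this replacement, and the expectation is a step no larger than the scatter, a 1.1-fold higher number from compound 1 to compound 4 (0.04 log units; within the scatter).

Compound 4 is thus expected to give about 4500 nM in this assay, within 1500 nM to 14000 nM.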

Compound 4, half-maximal inhibitory concentration: 8700 nM
For compound 4 the middle estimate is 1.9-fold (0.29 log units) below the measured one; the measured number falls inside the stated range.
By their numbers in this assay, from the lowest: compound 1; then compounds 4 and 3 (each within the scatter of the next).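

In this assay, going by these compounds alone, phenyl in place of cyclohexyl on a saturated chain carbon bound to a saturated ring carbon gives the first measured step for this substituent (a 2.1-fold higher number from compound 1 to compound 4 (0.33 log units; beyond the scatter)). The step is modest but beyond the scatter, so this place responds to the identity of the ring and not only to configuration. Both groups have the same heavy-atom count and neither has hydrogen-bond donors or acceptors, so the step goes with an aromatic ring replacing a non-aromatic one, although nothing available accounts for it.

The compounds shown leave open whether the same replacement gives a similar step in the configuration of compound 3. They also leave open how an amine, a carboxylic acid or a longer chain at this place would compare with cyclohexyl and phenyl.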